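The source may report more compounds than this note shows. Statements on the series, on what has been measured and on what is new or still open speak of the compounds shown alone.

All three compounds in this set share one core and differ only in the group attached to the outer six-membered carbon ring. Within the data shown here, compound 1 `OC[C@H](NC[C@H]1NC[C@H](O)[C@@H]1O)c1ccc(-c2ccccc2)cc1` is the first of them. In a functional assay on A549 cells (Homo sapiens) for cytotoxicity, read by colorimetric assay, with a stated time of 72 h (on this read-out higher numbers stand for weaker inhibition and lower numbers for stronger inhibition), compound 1 gives > 200000 nM, and this is a limit of the assay rather than a measured number. Compound 2 `OC[C@H](NC[C@H]1NC[C@H](O)[C@@H]1O)c1ccc(-c2ccsc2)cc1` carries a thiophen-3-yl group on that ring. In this assay compound 2 is reported simply as "not active" (no number reported), with no number attached. The two known results thus point the same way: neither compound shows measurable inhibition, and the only numerical entry is a limit, (the limit of > 200000 nM in this assay, at which 1 of the 2 values shown sits). Compound 3 `C=CCOc1ccc([C@H](CO)NC[C@H]2NC[C@H](O)[C@@H]2O)cc1` has not been tested. It differs from compound 2 by allyloxy in place of thiophen-3-yl on an aromatic carbon. Among the measured compounds shown here, with no measured step between compounds of this set to build on, no change beyond the usual scatter can be expected in this assay. Compound 3 is therefore expected to give about 200000 nM in this assay, within a range of 50000 nM to 1000000 nM, most likely reported again only as a limit.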

Compound 3, half-maximal inhibitory concentration: > 200000 nM
Compound 3 was reported as a limit (the forecaster's own chance of this, stated with the estimate: 85%); the middle value sits exactly at the limit.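

No step can be read among compound 1, compound 2 and compound 3 in this assay, because none of the three has an actual number, only a limit or the words "not active": the limit of > 200000 nM in this assay, at which 2 of the 3 values shown sit. The compounds shown leave open whether any group on the outer six-membered carbon ring would give measurable inhibition in these cells.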